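Nitro to trifluoromethyl on the carbonyl-carbon phenyl

A few compounds are considered here, and "the series" means these few. Any claim that something is new, unique, unknown or untested is made for them only; others in the source may bear on it.

Within the data shown here, compound 1 `O=C(Nc1nc(-c2ccccc2)nc2c1nnn2Cc1ccccc1)c1cccc([N+](=O)[O-])c1` gives 77 nM in an assay (strain Wistar) for displacement of a labelled ligand from adenosine receptor A1 (Rattus norvegicus), read by scintillation counting (on this read-out lower numbers stand for stronger inhibition and higher numbers for weaker inhibition), the highest of the three numbers measured so far. Compound 2 `Nc1ccc(C(=O)Nc2nc(-c3ccccc3)nc3c2nnn3Cc2ccccc2)cc1` gives 7.1 nM and compound 3 `O=C(Nc1nc(-c2ccccc2)nc2c1nnn2Cc1ccccc1)c1ccc([N+](=O)[O-])cc1` gives 24 nM; the steps of an 11-fold lower number from compound 1 to compound 2 (1.04 log units; beyond the scatter) and a 3.2-fold lower number from compound 1 to compound 3 (0.51 log units; beyond the scatter) both run toward lower numbers, while a 3.4-fold higher number from compound 2 to compound 3 (0.53 log units; beyond the scatter). Compound 4 `O=C(Nc1nc(-c2ccccc2)nc2c1nnn2Cc1ccccc1)c1cccc(C(F)(F)F)c1` differs from compound 1 in a single place on the phenyl attached to the carbonyl carbon: trifluoromethyl in place of nitro on an aromatic carbon. Among the measured compounds shown here, no measured step exchanges nitro for trifluoromethyl; the two steps from compound 1 change either the position of nitro or swap it for amino. For the measured compounds named here, with no direct precedent, the expected step of a 1.3-fold lower number from compound 1 to compound 4 (0.11 log units; within the scatter) is kept small, close to the scatter. Compound 4 is estimated at 60 nM, with a range of 20 nM to 200 nM.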

Compound 4, inhibition constant: 163 nM
For compound 4 the middle estimate is 2.7-fold (0.43 log units) below the measured one; low and high end bracket the measured number.
By their numbers in this assay, from the lowest: compound 2; then compound 3; then compound 1; then compound 4.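

In this assay the exchange of nitro for trifluoromethyl on this aromatic carbon gives a 2.1-fold higher number from compound 1 to compound 4 (0.33 log units; beyond the scatter) and the highest number of the four, so trifluoromethyl does not match nitro at this position. The distance to the other phenyl groups grows, with a 6.8-fold higher number from compound 3 to compound 4 (0.83 log units; beyond the scatter) and a 23-fold higher number from compound 2 to compound 4 (1.36 log units; beyond the scatter) on the same read-out. Nothing available explains this step. Open, going by these compounds, is whether a nitrile or a methoxy group on this aromatic carbon would stay nearer to nitro. Also open, on these data alone, is whether trifluoromethyl in place of the nitro of the 4-nitrophenyl would move the number the same way.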